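This account rests on a few compounds, and the source may have more. Where it says the series, first, only, none or still open, it means among the compounds named here.

Measured compounds:
- compound 1, `CC/C=C\Cn1c(Cc2cc(OC)c(OC)c(OC)c2)nc2c(N)ncnc21` — 64600 nM in a functional assay on MCF7 cells (Homo sapiens) for antiproliferative activity; a higher number here means a weaker inhibitor, a lower number a stronger inhibitor
- compound 2, `COc1cc(Cc2nc3c(N)nc(F)nc3n2CC2CCC2)cc(OC)c1OC` — 40700 nM in this assay

Of the compounds shown here, two sharing the same core have been measured. In this assay compound 1 gives 64600 nM, and compound 2 gives 40700 nM. The two numbers lie within the scatter of each other, so neither compound can be set apart from the other on these data; both sit in the weak range.

The step under study leads from compound 1 to compound 3, `C=CCCn1c(Cc2cc(OC)c(OC)c(OC)c2)nc2c(N)ncnc21`, which is yet to be measured in this assay. The change is allyl in place of but-1-en-1-yl on a saturated chain carbon bound to an aromatic nitrogen. One chain carbon is lost and the double bond shifts within the chain, while donors, acceptors and charge are unchanged.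

Going by the values given here, no step between measured compounds touches this part of the molecule, so there is no measured precedent to lean on. With so small a change to the chain on the aromatic nitrogen, compound 3 is expected to stay close to compound 1, with the estimated step of a 1.1-fold lower number from compound 1 to compound 3 (0.03 log units; within the scatter) not exceeding the scatter in either direction. Compound 3 is therefore estimated at 60000 nM, with a range from 20000 nM to 180000 nM.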

Compound 3, half-maximal inhibitory concentration: 40700 nM
The estimate for compound 3 lay 1.5-fold (0.17 log units) above the measured number, within the range that was stated.
By their numbers in this assay, from the lowest: compounds 2, 3 and 1 (each within the scatter of the next).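

The step of a 1.6-fold lower number from compound 1 to compound 3 (0.20 log units; within the scatter) in this assay gives this chain on the aromatic nitrogen its first measured comparison, and allyl in place of but-1-en-1-yl leaves compound 1 and compound 3 indistinguishable. Losing one chain carbon while the double bond shifts within the chain therefore does not set the two compounds apart, and compound 3, like compound 1, sits in the weak range. No evidence bears on this result, so the data cannot say why these two compounds read alike.

The compounds shown leave open whether any group at this position can move the number beyond the scatter, a question that a much longer chain, a chain ending in an amine or a carboxylic acid, or a benzyl group would address. Compound 2 differs from compound 3 in more than one place, so it gives no separate reading of its cyclobutylmethyl chain or of its fluorine on the shared core, and the effect of each remains unresolved.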